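The compounds below may be only part of what the source reports. "The series", "measured", "known", "first", "only" and "open" are said of these compounds alone.

Among the compounds with values here, in a physicochemical assay for solubility, read by HPLC, in phosphate buffer, measured as kinetic solubility, with a stated time of 1 h, at pH 7.4, tested at 250 uM (a higher number here means a more soluble compound, a lower number a less soluble compound), compound 1 `CN1CCC(c2ccc3c(c2)oc(=O)n3C(=O)NCCCCc2ccc(F)cc2)CC1` gives 22000 nM, the only true number among the three measured compounds. Compound 2 `CC(C)CN1CCC(c2ccc3c(c2)oc(=O)n3C(=O)NCCCCc2ccccc2)CC1` returns only a limit, < 1000 nM. Compound 3 `CCN1CCN(c2ccc3c(c2)oc(=O)n3C(=O)NCCCCc2ccccc2)CC1` also returns only a limit, < 1000 nM. Compound 4 `CC(C)CNC(=O)n1c(=O)oc2cc(C3CCN(C)CC3)ccc21` departs from compound 1 with isopropyl in place of 3-(4-fluorophenyl)propyl on a saturated chain carbon bound to an amide-type nitrogen. Within the data shown here, the one measured step, a step that the two limits leave unreadable from compound 2 to compound 3, lies at a different place and has no readable size, so no measured step bears on this change. The expectation therefore rests on the structural change alone and points upward in this assay, with an estimated move of a 2.7-fold higher number from compound 1 to compound 4 (0.44 log units; beyond the scatter). For compound 4 the expected value is 60000 nM, estimated to lie between 20000 nM and 180000 nM.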

Compound 4, solubility: 240000 nM
Compound 4: the middle estimate sits 4.0-fold (0.60 log units) below what was measured; measured number outside the range, above it.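

In this assay, isopropyl in place of 3-(4-fluorophenyl)propyl on a saturated chain carbon bound to an amide-type nitrogen gives the only readable step among the compounds shown, an 11-fold higher number from compound 1 to compound 4 (1.04 log units; beyond the scatter). This shows that the read-out is sensitive to the group at this place, a point the earlier compounds could not show, as their one step cannot be read: the limit of < 1000 nM in this assay, at which 2 of the 4 values shown sit.

This single step cannot separate the loss of the aromatic ring, the fluorine and the chain length. From the compounds shown here alone, what a cyclohexyl group or a morpholine at this place would give in this assay remains open.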